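Replacing the side group of compound 2: expected cytotoxicity of compound 4

The compounds below may be only part of what the source reports. "The series", "measured", "known", "first", "only" and "open" are said of these compounds alone.

Working notes on the shared core, read in an ADME assay on Vero cells (Chlorocebus sabaeus) for cytotoxicity, with a stated time of 7 days; on this read-out lower numbers stand for higher toxicity in this test and higher numbers for lower toxicity in this test. Compound 1 `COc1ccc2[nH]c(C(=O)N3CC(=O)N(Cc4ccccc4)[C@@H](CCc4ccccc4)C3)cc2c1` gives only a limit in this assay, > 30000 nM. Compound 2 `COc1ccc2[nH]c(C(=O)N3CC(=O)N(Cc4ccccc4)[C@@H](CN4C(=O)c5ccccc5C4=O)C3)cc2c1` gives 41000 nM, and compound 3 `COc1ccc2[nH]c(C(=O)N3CC(=O)N(Cc4cccc(OC(F)F)c4)[C@@H](CN4CC5CCC4C5)C3)cc2c1` gives 26900 nM. Compound 2 stands highest of the two numbers shown; the nearest is compound 3, within the scatter, and the third value is a limit. Among the compounds with values here, the one step that touches compound 2 is a step that the limit leaves unreadable from compound 1 to compound 2, unreadable because of the limit of > 30000 nM in this assay, at which 1 of the 3 values shown sits, so it sets no direction.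

Compound 4 `COc1ccc2[nH]c(C(=O)N3CC(=O)N(Cc4ccccc4)[C@@H](CN4CCCc5ccccc54)C3)cc2c1` differs from compound 2 by a group of 10 heavy atoms (9 carbon, 1 nitrogen; one six-membered non-aromatic ring with 1 hetero atom, one six-membered aromatic ring of carbon only) in place of a group of 11 heavy atoms (8 carbon, 1 nitrogen, 2 oxygen; one five-membered non-aromatic ring with 1 hetero atom, one six-membered aromatic ring of carbon only), on a saturated chain carbon bound to a saturated ring carbon. Within the data shown here, no measured step covers this change; compound 3 carries a different group at the same place and shows no separation from compound 2 beyond the scatter. The expectation is therefore a step of a 1.4-fold lower number from compound 2 to compound 4 (0.14 log units; within the scatter), that is, none beyond the scatter. For compound 4 the estimated value in this assay is 30000 nM, with a range from 12000 nM to 70000 nM.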

Compound 4, half-maximal cytotoxic concentration: > 100000 nM
Compound 4: a limit, no number; the forecaster's own chance of this, stated with the estimate: 35%; at least 3.3-fold (0.52 log units) between middle value and limit.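

In this assay, within the data shown here, the 1,2,3,4-tetrahydroquinolin-1-yl group, on a saturated chain carbon bound to a saturated ring carbon, gives an at least 2.4-fold higher number from compound 2 to compound 4 (0.38 log units; beyond the scatter), the only readable step at this place and one that shows this single change can move the read-out beyond the scatter. Compound 4 gives > 100000 nM, which is a limit of the assay and not a number. The steps from compound 1 to compound 2 and to compound 4 cannot be read, so benzyl at this place has no readable comparison with either group.

From the compounds shown here alone, how far the number of compound 4 lies past its limit remains open. Also open, going by these compounds, is whether a carboxylic acid or an open-chain amine such as diethylamino at the same place, with the rest of compound 4 unchanged, would give a readable value.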